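This account rests on a few compounds, and the source may have more. Where it says the series, first, only, none or still open, it means among the compounds named here.

In a functional assay on WM 266-4 cells (Homo sapiens) for antiproliferative activity, read by MTT assay, with a stated time of 24 h (a lower number here means a stronger inhibitor of growth, a higher number a weaker inhibitor of growth), compound 1 `O=C(c1ccc(Cl)nc1)N1N=C(c2ccc(Cl)cc2)CC1c1ccc(Cl)cc1` gives 9890 nM and compound 2 `Cc1ccc(C(=O)N2N=C(c3ccc(Cl)cc3)CC2c2ccc(Cl)cc2)cn1` gives 3790 nM which is the lower of these two numbers. Compound 3 `Cc1ccc(C(=O)N2N=C(c3ccc(Cl)cc3)CC2c2ccc(Br)cc2)cn1` has not yet been measured. Its structure departs from that of compound 2 in one place: bromo in place of chloro on an aromatic carbon that is, bromo in place of chloro on an aromatic carbon, read one bond further out as 4-chlorophenyl to 4-bromophenyl. Among the measured compounds shown here, only one measured step is available, and it bears on this change only indirectly. For the measured compounds named here, that modest step is a 2.6-fold lower number from compound 1 to compound 2 (0.42 log units; beyond the scatter) and it concerns methyl in place of chloro at a different place, so no measured step covers bromo. The expectation is therefore for no step beyond the scatter, and the estimated change is a 1.1-fold lower number from compound 2 to compound 3 (0.03 log units; within the scatter) in this assay as a small shift at most. Compound 3 is estimated at 3500 nM with an expected range from 1600 nM to 7800 nM in this measurement.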

Compound 3, concentration for 50% growth inhibition: 7650 nM
Compound 3: the middle estimate sits 2.2-fold (0.34 log units) below what was measured; low and high end bracket the measured number.
By their numbers in this assay, from the lowest: compound 2; then compounds 3 and 1 (each within the scatter of the next).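

In this assay, among the compounds shown here, bromo in place of chloro on this aromatic carbon, para to a large group, gives a 2.0-fold higher number from compound 2 to compound 3 (0.31 log units; beyond the scatter) and so provides the first measured change at this position. The earlier step concerned a different place, whereas this one shows that even an exchange of one halogen for another here can move the number modestly beyond the scatter, with chloro the better of the two in this single pair. Nothing measured on these compounds explains the rise.

The compounds shown leave open how a fluoro, a methyl or an amine on the same carbon would compare with chloro and bromo. They also leave open whether bromo would have a similar effect on the other 4-chlorophenyl group or alongside the chloro group carried by compound 1.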